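Phenylcarbamoyl for 4-cyanophenyl on a sulfonamide nitrogen

The compounds below may be only part of what the source reports. "The series", "measured", "known", "first", "only" and "open" are said of these compounds alone.

Compound 1 `CC1(C)C=C(n2ccccc2=O)c2cc(S(=O)(=O)NCCO)ccc2O1`: 87.9%
Compound 2 `CC1(C)C=C(n2ccccc2=O)c2cc(S(=O)(=O)Nc3ccccc3)ccc2O1`: 7.85%; 88% (2 entries)
Compound 3 `CC1(C)C=C(n2ccccc2=O)c2cc(S(=O)(=O)Nc3ccc(C#N)cc3)ccc2O1`: 90.8%

All three share one core and differ only in the group on the sulfonamide nitrogen. In a functional assay on the whole organism (trachea) with Rattus norvegicus as the target (on this read-out lower numbers stand for smaller maximal responses and higher numbers for larger maximal responses), compound 3 gives 90.8%, the higher of the two single numbers; compound 1 stands nearest, and the step of a number 2.9 percentage points higher from compound 1 to compound 3 (within the scatter) lies within the scatter. Compound 2 has two entries, (the several entries of compound 2 in this assay, 7.85%; 88% (2 entries)), which do not agree with each other.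

Compound 4 `CC1(C)C=C(n2ccccc2=O)c2cc(S(=O)(=O)NC(=O)Nc3ccccc3)ccc2O1` has not yet been measured. It differs from compound 3 by phenylcarbamoyl in place of 4-cyanophenyl on a sulfonamide nitrogen. For the measured compounds named here, the only measured step at this nitrogen, a number 2.9 percentage points higher from compound 1 to compound 3 (within the scatter), stayed within the scatter, and compound 2, which carries a phenyl group on that nitrogen, reached a high maximal response in one of its two entries. Compound 4 is therefore expected to reach a similar maximal response, so that the expected step of a number 5.8 percentage points lower from compound 3 to compound 4 (within the scatter) stays within the scatter. The estimate for compound 4 is 85%, between 50% and 100%; the range is kept wide because the several entries of compound 2 in this assay, 7.85%; 88% (2 entries) shows how far repeats of a single compound can differ here.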

Compound 4, largest response reached (Emax), in percent of the reference or control that the assay uses: 99.5%
Compound 4: the middle estimate sits 14.5 percentage points below what was measured; the range from low to high includes it.
By their numbers in this assay, from the lowest: compounds 1, 3 and 4 (each within the scatter of the next, the first and the last beyond it).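

In this assay, putting phenylcarbamoyl on the sulfonamide nitrogen in place of 4-cyanophenyl gives a number 8.7 percentage points higher from compound 3 to compound 4 (within the scatter), so this nitrogen accepts a group with a carbonyl and an amide hydrogen without a readable change from compound 3. Set against 2-hydroxyethyl, the same group gives a number 11.6 percentage points higher from compound 1 to compound 4 (beyond the scatter), the first step at this nitrogen to pass the scatter, though only a modest one. Compound 3 stays within the scatter of both compound 1 and compound 4, so the three do not separate into clean levels.

From the compounds shown here alone, whether a methyl group or a chain ending in a carboxylic acid on this nitrogen would keep the response remains open. Where compound 2, with plain phenyl on that nitrogen, belongs also stays unsettled: the several entries of compound 2 in this assay, 7.85%; 88% (2 entries)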